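Swapping methoxy for phenyl on a weak histone deacetylase 4 series

The compounds below may be only part of what the source reports. "The series", "measured", "known", "first", "only" and "open" are said of these compounds alone.

Compound 3 `COc1ccc(NC(=O)CCCCCCNC(=O)C(O)(O)C(F)(F)F)cc1` gives 1600000 nM in an assay on isolated protein for inhibition of histone deacetylase 4 (Homo sapiens), read by chemiluminescence, with a stated time of 3 h (on this read-out lower numbers stand for stronger inhibition and higher numbers for weaker inhibition), the lowest of the three numbers shown, yet it sits within the scatter of both compound 2 `O=C(CCCCCCNC(=O)C(O)(O)C(F)(F)F)Nc1ncc(-c2ccc(Br)cc2)s1` at 1700000 nM and compound 1 `COc1ccc(-c2cnc(NC(=O)CCCCCCNC(=O)C(O)(O)C(F)(F)F)s2)cc1` at 2500000 nM. Compound 4 `O=C(CCCCCCNC(=O)C(O)(O)C(F)(F)F)Nc1ccc(-c2ccccc2)cc1` differs from compound 3 by phenyl in place of methoxy on an aromatic carbon. Within the data shown here, the only measured step that touches the same position, a 1.5-fold lower number from compound 1 to compound 2 (0.17 log units; within the scatter), stayed within the scatter, and no step shows a phenyl entering. With all three numbers close together, he expects no change beyond the scatter and estimates compound 4 at 1500000 nM in this assay, with a range from 600000 nM to 4000000 nM, a step of a 1.1-fold lower number from compound 3 to compound 4 (0.03 log units; within the scatter).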

Compound 4, half-maximal inhibitory concentration: 1100000 nM
The estimate for compound 4 lay 1.4-fold (0.13 log units) above the measured number, within the range that was stated.
By their numbers in this assay, from the lowest: compounds 4, 3, 2 and 1 (each within the scatter of the next, the first and the last beyond it).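

In this assay, among these compounds, the step of a 1.5-fold lower number from compound 3 to compound 4 (0.16 log units; within the scatter) is the first to show a phenyl entering, and it shows that this group, with its six-membered aromatic ring of carbon only, can take the place of methoxy without moving the number beyond the scatter. The change also removes the hydrogen-bond acceptor of methoxy, and that loss likewise leaves the number within the scatter. No measurement shown here offers an explanation for this result. Going by these compounds, what remains open is whether an amine or a carboxylic acid on this aromatic carbon would move the number beyond the scatter.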